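Working notes: fluoro for methoxy, compound 2 to compound 3

A few compounds are considered here, and "the series" means these few. Any claim that something is new, unique, unknown or untested is made for them only; others in the source may bear on it.

Measured so far in a functional assay on A549 cells (Homo sapiens) for antiproliferative activity, read by MTT assay, with a stated time of 48 h; on this read-out lower numbers stand for stronger inhibition and higher numbers for weaker inhibition:

Compound 1 `COc1ccc(/C=C/c2cc(OC)cc(OC)c2/C=C/C(=O)c2ccccc2)cc1`: 3.9 ug/mL
Compound 2 `COc1ccc(/C=C/c2cc(OC)cc(OC)c2/C=C/C(=O)c2ccc(OC)cc2)cc1`: 4.5 ug/mL

Compound 2 stands at the highest of the two numbers; the nearest is compound 1, with a 1.2-fold higher number from compound 1 to compound 2 (0.06 log units; within the scatter), so no order between the two can be claimed.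

Compound 3 `COc1ccc(/C=C/c2cc(OC)cc(OC)c2/C=C/C(=O)c2ccc(F)cc2)cc1` differs from compound 2 by fluoro in place of methoxy on an aromatic carbon. Among the compounds with values here, the only measured step that bears on this position is the one from compound 1 to compound 2, in which the same aromatic carbon was changed, and that step stayed within the scatter. Nothing in the series shows a change at this carbon moving the number beyond the scatter, so a step beyond it is not expected here either; the estimate is a 1.1-fold lower number from compound 2 to compound 3 (0.03 log units; within the scatter). For compound 3 the expected value is therefore 4.2 ug/mL, with a range of 2 ug/mL to 9 ug/mL.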

Compound 3, half-maximal inhibitory concentration: 6.6 ug/mL
For compound 3 the middle estimate is 1.6-fold (0.20 log units) below the measured one, and the stated range covers the measured number.
By their numbers in this assay, from the lowest: compounds 1, 2 and 3 (each within the scatter of the next).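

In this assay fluoro in place of methoxy gives a 1.5-fold higher number from compound 2 to compound 3 (0.17 log units; within the scatter) and fluoro in place of hydrogen gives a 1.7-fold higher number from compound 1 to compound 3 (0.23 log units; within the scatter) on the same aromatic carbon, para to a large group. Within the data shown here, this carbon has now carried hydrogen, methoxy and fluoro, where the earlier compounds showed only the first two, and every step among the three stays within the scatter, so no order among them can be claimed and a halogen at this carbon has not yet moved the number beyond it. No measured evidence bears on the reason for these numbers.

Going by these compounds, whether an amine, a carboxylic acid or a longer alkoxy chain on this carbon would move the number beyond the scatter stays open. Also open, on these data alone, is whether the same replacements would behave alike elsewhere on the shared core.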